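Replacing the fluoro on the benzamide ring with methylpiperazine

The compounds below may be only part of what the source reports. "The series", "measured", "known", "first", "only" and "open" are said of these compounds alone.

Of the compounds shown here, three sharing one core have been measured in an assay on Sf21 cells for inhibition of high affinity nerve growth factor receptor (Homo sapiens), read by HTRF, with a stated time of 30 min, in the presence of a further agent that is not named here; on this read-out lower numbers stand for stronger inhibition and higher numbers for weaker inhibition. Compound 2 `CC1(C)c2[nH]nc(NC(=O)c3ccc(F)cc3)c2CN1Cc1cccc(F)c1F` gives 210 nM, the lowest of the three numbers. Compound 3 `CC1(C)c2[nH]nc(NC(=O)c3ccc(F)cc3)c2CN1Cc1cc(F)cc(F)c1` gives 350 nM, and the step of a 1.7-fold higher number from compound 2 to compound 3 (0.22 log units; within the scatter) lies within the scatter, so the two cannot be ranked. Among the compounds with values here, compound 1 `CC1(C)c2[nH]nc(NC(=O)c3ccccc3)c2CN1Cc1cccc(Br)c1` gives 940 nM, a number beyond the scatter from compound 2; compound 1 differs from compound 2 in two places, so no single step is drawn between them.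

Compound 4 `CN1CCN(c2ccc(C(=O)Nc3n[nH]c4c3CN(Cc3cccc(F)c3F)C4(C)C)cc2)CC1` is derived from compound 2 by 4-methylpiperazin-1-yl in place of fluoro on an aromatic carbon. Within the data shown here, the one measured step, from compound 2 to compound 3, concerns the other aromatic ring, the one on the saturated chain carbon bound to the ring amine nitrogen, and says nothing about the benzamide ring; compound 1 carries no group at that position but also differs elsewhere. Nothing measured here therefore bears directly on the change to compound 4, and the expectation rests on the absence of contrary evidence rather than on a precedent. A step no larger than the scatter, in either direction, is expected for a 1.3-fold lower number from compound 2 to compound 4 (0.12 log units; within the scatter). Compound 4 is accordingly estimated at 160 nM, with a range from 40 nM to 650 nM in this assay.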

Compound 4, half-maximal inhibitory concentration: 17 nM
The estimate for compound 4 lay 9.4-fold (0.97 log units) above the measured number, outside the stated range (below it).
By their numbers in this assay, from the lowest: compound 4; then compounds 2 and 3 (each within the scatter of the next); then compound 1.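

In this assay, a 12-fold lower number from compound 2 to compound 4 (1.09 log units; beyond the scatter) marks the exchange of fluoro for 4-methylpiperazin-1-yl on the benzamide ring, para to a large group, so this position is not indifferent to what it carries and tolerates a group much larger than fluoro. The only earlier single-place step, a 1.7-fold higher number from compound 2 to compound 3 (0.22 log units; within the scatter), concerned the other aromatic ring and stayed within the scatter, whereas this change is the first single-place step shown to lie beyond it. No measurement is available to explain the shift, and the data do not separate the contributions of the ring, its nitrogens and its methyl group.

The compounds shown leave open which part of the entering group matters, a question that an unsubstituted piperazine, a morpholine or an open-chain dimethylamino group at this position would help to settle. From the compounds shown here alone, it also remains open whether 4-methylpiperazin-1-yl has a similar effect when the 2,3-difluorophenyl group is replaced by the 3,5-difluorophenyl group of compound 3.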